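The compounds below may be only part of what the source reports. "The series", "measured", "known", "first", "only" and "open" are said of these compounds alone.

Working notes on the series, read in a functional assay on the whole organism with Mus musculus as the target; a lower number here means that less compound is needed, a higher number that more compound is needed for the effect. Compound 2 `Cc1cc(C(C)CC(=O)O)ccc1-c1noc(-c2ccc(OC(C)C)c(C(F)(F)F)c2)n1` gives 0.1 mg/kg, compound 1 `Cc1cc([C@@H]2C[C@H]2C(=O)O)ccc1-c1noc(-c2ccc(OC(C)C)c(C(F)(F)F)c2)n1` gives 0.2 mg/kg and compound 3 `Cc1nc(CCC(=O)O)ccc1-c1noc(-c2ccc(OC(C)C)c(C#N)c2)n1` gives 0.2 mg/kg, so all three stand within the scatter of each other. Compound 4 `Cc1cc(CC(C)C(=O)O)ccc1-c1noc(-c2ccc(OC(C)C)c(C(F)(F)F)c2)n1` is not yet measured. Its difference from compound 2 is 2-carboxypropyl in place of 1-(carboxymethyl)ethyl on an aromatic carbon: the same atoms joined differently, with 2-carboxypropyl in place of 1-(carboxymethyl)ethyl. Among the measured compounds shown here, the one measured step at this place is a 2.0-fold lower number from compound 1 to compound 2 (0.30 log units; within the scatter), which stays within the scatter. For the measured compounds named here, no measured step covers this exact exchange, so no change beyond the scatter is expected in this assay. The expected step is a 1.5-fold higher number from compound 2 to compound 4 (0.18 log units; within the scatter). The estimate for compound 4 is 0.15 mg/kg, with an expected range of 0.05 mg/kg to 0.5 mg/kg.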

Compound 4, dose for half-maximal effect: 0.1 mg/kg
Compound 4: the middle estimate sits 1.5-fold (0.18 log units) above what was measured, and the stated range covers the measured number.
By their numbers in this assay, from the lowest: compounds 2, 4, 1 and 3 (each within the scatter of the next).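

In this assay, 2-carboxypropyl in place of 1-(carboxymethyl)ethyl on this aromatic carbon shows no change at the digits printed from compound 2 to compound 4 (within the scatter), so this position accepts the same atoms joined differently without a change beyond the scatter. The open-chain 2-carboxypropyl in place of 2-carboxycyclopropyl shows a 2.0-fold lower number from compound 1 to compound 4 (0.30 log units; within the scatter), which places the ring-closed side chain and both branched chains within the scatter at this position. Going by these compounds, whether a longer chain carrying the carboxylic acid, or a primary amide in place of that acid, would keep the number in this range stays open. No evidence is available that bears on this result.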